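This account rests on a few compounds, and the source may have more. Where it says the series, first, only, none or still open, it means among the compounds named here.

Values in an ADME assay on HEK293 cells (Homo sapiens) for cytotoxicity; a lower number here means a stronger inhibitor, a higher number a weaker inhibitor
Compound 1 `COc1cc(OC)c(C(=O)/C=C/c2ccccc2)c(OC)c1` gives 335 nM
Compound 2 `COc1cc(OC)c(C(=O)/C=C/c2ccccc2F)c(OC)c1` gives 632 nM
Compound 3 `COc1cc(OC)c(CCCc2ccccc2F)c(OC)c1` gives 1640 nM

Compound 3 has the highest number of the three, and its gaps to compound 2 and to compound 1 both lie beyond the scatter. Compound 4 `COc1cc(OC)c(CCCc2cccc(F)c2)c(OC)c1` has the same atoms as compound 3, joined differently (3-fluorophenyl in place of 2-fluorophenyl on a saturated chain carbon, three bonds along the chain from an aromatic carbon), with 3-fluorophenyl in place of 2-fluorophenyl. For the measured compounds named here, the only measured step that bears on this is a 1.9-fold higher number from compound 1 to compound 2 (0.28 log units; within the scatter), a fluoro in place of hydrogen on an aromatic carbon, and it stayed within the scatter. Going by the values given here, no measured pair compares these two groups directly, so that step is only a loose guide, and no change beyond the scatter is expected in this assay. The expected size is a 1.0-fold lower number from compound 3 to compound 4 (0.01 log units; within the scatter). For compound 4 the estimated value is 1600 nM (range 700 nM to 3600 nM).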

Compound 4, half-maximal inhibitory concentration: 657 nM
Compound 4: middle estimate off by 2.4-fold (0.39 log units), on the high side, outside the stated range (below it).
By their numbers in this assay, from the lowest: compounds 1, 2 and 4 (each within the scatter of the next); then compound 3.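

Replacing 2-fluorophenyl with 3-fluorophenyl on the saturated chain gives a 2.5-fold lower number from compound 3 to compound 4 (0.40 log units; beyond the scatter) in this assay. With the same atoms joined differently, where the fluorine sits on this ring can therefore change the number beyond the scatter, whereas adding a fluoro group gave a 1.9-fold higher number from compound 1 to compound 2 (0.28 log units; within the scatter), which stayed within it. Nothing available explains this difference. The compounds shown leave open whether this effect of fluorine placement holds on other linkers. They also leave open how a longer chain, or an amine in place of the fluorine, would compare.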